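Series notes: compound 3 to compound 4 in EP3 binding

The compounds below may be only part of what the source reports. "The series", "measured", "known", "first", "only" and "open" are said of these compounds alone.

Measured in an assay on CHO cells for displacement of a labelled ligand from prostaglandin E2 receptor EP3 subtype (Mus musculus), read by scintillation counting, with a stated time of 60 min; on this read-out higher numbers stand for weaker inhibition and lower numbers for stronger inhibition:
compound 1 `O=C(O)CCCSCCN1C(=O)CC[C@@H]1/C=C/[C@@H](O)Cc1cccc(N2Cc3ccccc3C2)c1`: > 10000 nM, a limit of the assay.
compound 2 `O=C(O)CCCSCCN1C(=O)CC[C@@H]1/C=C/[C@@H](O)Cc1cccc(-c2nc3ccccc3s2)c1`: > 10000 nM, a limit of the assay.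
compound 3 `O=C(O)c1csc(SCCN2C(=O)CC[C@@H]2/C=C/[C@@H](O)Cc2cccc(-c3ccc(Cl)cc3)c2)n1`: > 10000 nM, a limit of the assay.

Compound 3 stands at the assay limit, where every value of the series sits (the limit of > 10000 nM in this assay, at which 3 of the 3 values shown sit). Among the compounds with values here, the one measured step, a step that the two limits leave unreadable from compound 1 to compound 2, is unreadable because both of its ends sit at the limit of > 10000 nM in this assay, at which 3 of the 3 values shown sit. Compound 4 `Cc1ccc2oc(-c3cccc(C[C@H](O)/C=C/[C@H]4CCC(=O)N4CCSc4nc(C(=O)O)cs4)c3)nc2c1` differs from compound 3 by 5-methyl-1,3-benzoxazol-2-yl in place of 4-chlorophenyl on an aromatic carbon. Within the data shown here, no measured step bears on this change, and compound 3 gives no readable anchor. The value of compound 4 is therefore estimated at 15000 nM, range 3000 nM to 60000 nM, most likely reported again only as a limit. The expected step from compound 3 to compound 4 is a step that the limit leaves unreadable from compound 3 to compound 4, not beyond the scatter.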

Compound 4, inhibition constant: > 10000 nM
Compound 4 ended at the assay's limit (the forecaster's own chance of this, stated with the estimate: 75%); the middle value does not contradict the limit.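

No step can be read from compound 3 to compound 4, because both values are limits of the assay: the limit of > 10000 nM in this assay, at which 4 of the 4 values shown sit.

The compounds shown leave open what change to this series, if any, would give a value inside the assay's readable range.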